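Shortening the ether chain on the shared core

This account rests on a few compounds, and the source may have more. Where it says the series, first, only, none or still open, it means among the compounds named here.

Compound 1 `CCCCCCCOc1cc(CCc2nc(C)c(CC)s2)nc(NCc2cc(Cl)cc(NC(=O)OC(C)C)c2)c1` and compound 2 `CCc1sc(CCc2cc(OCC3(C)CC3)cc(NCc3cc(Cl)cc(NC(=O)OC(C)C)c3)n2)nc1C` share one core and differ only in the group carried on the ether oxygen. For the measured compounds named here, in an assay on cells for binding affinity to Neuropeptide Y receptor type 1 (Homo sapiens) (on this read-out higher numbers stand for weaker inhibition and lower numbers for stronger inhibition), compound 1 gives 72 nM, the higher of the two numbers measured so far; compound 2 gives 17 nM. Going by the values given here, the single measured step, a 4.2-fold lower number from compound 1 to compound 2 (0.63 log units; beyond the scatter), shows that exchanging the hexyl for a small branched group lowers the number beyond the scatter.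

Compound 3 `CCc1sc(CCc2cc(OCC(C)(C)C)cc(NCc3cc(Cl)cc(NC(=O)OC(C)C)c3)n2)nc1C` has not been measured. It differs from compound 1 by tert-butyl in place of hexyl on a saturated chain carbon bound to an oxygen on an aromatic ring. Among the compounds with values here, only the step from compound 1 to compound 2 bears on this change; it was modest and beyond the scatter, and the tert-butyl of compound 3 is, like the 1-methylcyclopropyl of compound 2, a short branched group sitting on the same carbon. A step in the same direction, possibly somewhat smaller, is therefore expected in this assay. For compound 3 the estimate is 25 nM, within 10 nM to 60 nM, which is expected to correspond to a 2.9-fold lower number from compound 1 to compound 3 (0.46 log units; beyond the scatter).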

Compound 3, half-maximal inhibitory concentration: 55 nM
Compound 3: middle estimate off by 2.2-fold (0.34 log units), on the low side, within the range that was stated.
By their numbers in this assay, from the lowest: compound 2; then compounds 3 and 1 (each within the scatter of the next).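

Working notes on the ether position: in this assay, tert-butyl in place of hexyl on a saturated chain carbon bound to an oxygen on an aromatic ring gives a 1.3-fold lower number from compound 1 to compound 3 (0.12 log units; within the scatter), so the smaller branched group does not separate compound 3 from compound 1 on this read-out. Tert-butyl in place of 1-methylcyclopropyl at the same place gives a 3.2-fold higher number from compound 2 to compound 3 (0.51 log units; beyond the scatter), which shows that these two short branched groups are not interchangeable here and that, among the three compounds, the clear drop in the number belongs to compound 2 alone, not to short branched groups in general. No measurement at hand offers a reason for the gap between these two groups.

Still open, from the compounds shown here alone, is whether the lower number of compound 2 depends on the ring of 1-methylcyclopropyl or on its methyl, a question that unsubstituted cyclopropyl or cyclobutyl on the same carbon would address. Also open, going by these compounds, is how this place responds to a chain carrying a hydroxyl or an amine, since the three groups compared here consist of carbon and hydrogen only.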